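Chloromethyl to iodomethyl in a glycosylated pyrazole series

This account rests on a few compounds, and the source may have more. Where it says the series, first, only, none or still open, it means among the compounds named here.

Compound 1 `NC(=O)c1cc(CCl)[nH]n1` is the smallest member of the set. In a functional assay on HeLa cells (Homo sapiens) (a lower number here means that less compound is needed, a higher number that more compound is needed for the effect), compound 1 gives > 100 ug/mL, which is a limit of the assay and not a number. Compound 2 `NC(=O)c1cc(CI)[nH]n1` carries the change iodo in place of chloro on a saturated chain carbon bound to an aromatic carbon is built on as well, namely (iodo in place of chloro on a saturated chain carbon bound to an aromatic carbon). In this assay compound 2 gives > 100 ug/mL, again a limit. The step that the two limits leave unreadable from compound 1 to compound 2 therefore cannot be read, because the limit of > 100 ug/mL in this assay, at which 2 of the 3 values shown sit, leaves both ends open. Compound 3 `CCOC(=O)c1cc(CCl)nn1C1O[C@@H](COC(C)=O)[C@H](OC(C)=O)[C@@H](OC(C)=O)[C@@H]1OC(C)=O` has a different core from compound 1; how the two cores differ is not broken down here. In this assay, among the measured compounds shown here, compound 3 gives 40 ug/mL, the only number among the three values so far. Compound 4 `CCOC(=O)c1cc(CI)nn1C1O[C@@H](COC(C)=O)[C@H](OC(C)=O)[C@@H](OC(C)=O)[C@@H]1OC(C)=O` has not yet been measured in this assay. Its place line and that of the change from compound 1 to compound 2 read word for word the same, so the change is the same, made on a core that does give a number. What the first pair shows about the chloro-to-iodo swap is nothing, because the limit of > 100 ug/mL in this assay, at which 2 of the 3 values shown sit, hides both values. With no measured size to lean on, the expected step of a 1.3-fold lower number from compound 3 to compound 4 (0.12 log units; within the scatter) is set near zero, wide enough to allow a move either way. Compound 4 is expected to come out near 30 ug/mL, estimated to lie between 8 ug/mL and 100 ug/mL.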

Compound 4, concentration for half-maximal effect: 2.5 ug/mL
Compound 4: the middle estimate sits 12-fold (1.08 log units) above what was measured; measured number outside the range, below it.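

On the core shared by compound 3 and compound 4, iodo in place of chloro on a saturated chain carbon bound to an aromatic carbon gives, in this assay, a 16-fold lower number from compound 3 to compound 4 (1.20 log units; beyond the scatter), so on this core the change has a large, readable effect. The same change on the core of compound 1 cannot be read, since the values on both sides are limits and not numbers, and so it cannot be said whether the effect carries over between the two cores: the limit of > 100 ug/mL in this assay, at which 2 of the 4 values shown sit. The series therefore holds a single measured instance of the change, which shows that it can matter on one core but does not show that it behaves alike on another, nor why it has this size.

Open, from the compounds shown here alone, is whether bromomethyl, set on the same saturated chain carbon of the core of compound 3, would track with chloromethyl or with iodomethyl, and whether a longer chain carrying the iodo would keep the step. Also open, going by these compounds, is whether the step survives with free hydroxyl groups in place of the acetate esters, or with a primary amide in place of the ethyl ester.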